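Substituent swaps on the aromatic ring: toxicity notes

The compounds below may be only part of what the source reports. "The series", "measured", "known", "first", "only" and "open" are said of these compounds alone.

Measured so far in a toxicity assay on the whole organism (strain Icem-CET (SPF Caw)) for cytotoxicity, with Mus musculus as the target; on this read-out lower numbers stand for an effect already at smaller amounts and higher numbers for an effect only at larger amounts of compound:
compound 1 `C=CCNC(=O)/C(C)=C(\C)c1ccc(Br)cc1`, 120 mg/kg
compound 2 `C=CCNC(=O)/C(C)=C(\C)c1ccc(C)cc1`, 100 mg/kg
compound 3 `C=CCNC(=O)/C(C)=C(\C)c1ccccc1`, 130 mg/kg

Compound 3 gives the highest of the three numbers, yet neither neighbour is set apart from it: a 1.1-fold higher number from compound 1 to compound 3 (0.03 log units; within the scatter) and a 1.3-fold higher number from compound 2 to compound 3 (0.11 log units; within the scatter) both stay within the scatter, as does a 1.2-fold lower number from compound 1 to compound 2 (0.08 log units; within the scatter). Across these three compounds, exchanging the group on the aromatic carbon has not moved the read-out beyond the usual spread.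

Compound 4 `C=CCNC(=O)/C(C)=C(\C)c1ccc(Cl)cc1` is the next member. It differs from compound 3 in a single place: chloro in place of hydrogen on an aromatic carbon. Within the data shown here, the steps that bear on this are the two that already alter the same position, a 1.1-fold higher number from compound 1 to compound 3 (0.03 log units; within the scatter) and a 1.3-fold higher number from compound 2 to compound 3 (0.11 log units; within the scatter), and both were within the scatter; the bromo case is the nearest point of comparison for the chloro now entering. No step beyond the scatter is therefore expected for a 1.1-fold lower number from compound 3 to compound 4 (0.03 log units; within the scatter) in this assay. Compound 4 is estimated at 120 mg/kg, with an expected range of 70 mg/kg to 220 mg/kg. Among the measured compounds shown here, the band is kept wide since only one example of each group has been measured.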

Compound 4, dose for half-maximal effect: 70 mg/kg
Beside the measured number, compound 4's estimate is 1.7-fold (0.23 log units) above it, and the stated range covers the measured number.
By their numbers in this assay, from the lowest: compounds 4, 2, 1 and 3 (each within the scatter of the next).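

Working notes after compound 4: in this assay, chloro on this aromatic carbon, para to a large group, gives a 1.9-fold lower number from compound 3 to compound 4 (0.27 log units; within the scatter) as the widest step at this position so far, yet even this step does not leave the scatter. Among these compounds, the exchanges a 1.4-fold lower number from compound 2 to compound 4 (0.15 log units; within the scatter) and a 1.7-fold lower number from compound 1 to compound 4 (0.23 log units; within the scatter) stay within it too, so at this position the read-out does not tell chloro from methyl or from bromo, and hydrogen, methyl, bromo and chloro now form a set of four with no step beyond the scatter and no compound going against that. Nothing at hand offers an explanation for the sizes of these steps.

The compounds shown leave open whether any group at this place can produce a step beyond the scatter in this assay at all, for example an amine, a carboxylic acid or a longer chain. They also leave open whether chloro on another aromatic carbon of the shared core would read the same as here, and each group at this position still rests on a single compound.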